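Butyl for phenyl in a cell toxicity test

This account rests on a few compounds, and the source may have more. Where it says the series, first, only, none or still open, it means among the compounds named here.

Among the measured compounds shown here, in a toxicity assay on THP-1 cells (Homo sapiens) for inhibition (on this read-out higher numbers stand for lower toxicity in this test and lower numbers for higher toxicity in this test), compound 1 (`COc1ccc(-c2cnc(NC(=O)c3ccc(F)cc3)n2-c2ccccc2)cc1`) gives 8800 nM as the only true number so far. Compound 2 (`Cn1c(-c2ccc(F)cc2)cnc1NC(=O)c1ccc(F)cc1`) reads > 100000 nM which is a limit of the assay and not a number. Compound 3 (`COc1ccc(-c2cnc(NC(=O)c3cccc(O)c3)n2C)cc1`) reads > 100000 nM and that too is only a limit.

Compound 4 (`CCCCn1c(-c2ccc(OC)cc2)cnc1NC(=O)c1ccc(F)cc1`) is still unmeasured. Its change from compound 1 is butyl in place of phenyl on an aromatic nitrogen. For the measured compounds named here, no measured pair isolates this swap, so the size of the step is a judgement. With compound 2 and compound 3 in view, a rise toward lower toxicity is expected because the limit of > 100000 nM in this assay, at which 2 of the 3 values shown sit, is where both of them sit. The estimated change is a 2.8-fold higher number from compound 1 to compound 4 (0.45 log units; beyond the scatter) and it is expected to exceed the usual scatter. For compound 4 the estimate in this assay is 25000 nM with an expected range from 7000 nM to 100000 nM as its bounds.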

Compound 4, half-maximal cytotoxic concentration: > 100000 nM
Compound 4 ended at the assay's limit; the forecaster's own chance of this, stated with the estimate: 30%; at least 4.0-fold (0.60 log units) between middle value and limit.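

In this assay, among the compounds shown here, this is the first pair that isolates the group on this aromatic nitrogen: butyl in place of phenyl gives an at least 11-fold higher number from compound 1 to compound 4 (1.05 log units; beyond the scatter). Compound 4 reads > 100000 nM, which is a limit of the assay and not a number, so the step has a lower bound but no exact size. Compound 1, with its phenyl, remains the only compound with a true number, and the others sit at the ceiling: the limit of > 100000 nM in this assay, at which 3 of the 4 values shown sit.

Still open, on these data alone, is what a cyclohexyl ring or a benzyl group would read on this nitrogen. Such groups could show whether a measurable value goes with phenyl alone or with ring groups more widely.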